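Thiophen-2-yl in place of thiophen-3-yl

This account rests on a few compounds, and the source may have more. Where it says the series, first, only, none or still open, it means among the compounds named here.

Measured in a functional assay for inhibition, with Homo sapiens as the target; a lower number here means tighter binding, a higher number weaker binding:
Compound 1 `O=C(O)CC/C=C\CC1COC(c2ccc(C(F)(F)F)cc2)OC1c1cccnc1`: 1780 nM
Compound 2 `O=C(O)CC/C=C\CC1COC(c2ccsc2)OC1c1cccnc1`: 1580 nM

Compound 2 stands at 1580 nM in this assay, and only compound 1 lies alongside it. The two values cannot be told apart, so neither compound ranks ahead of the other. The next structure is compound 3 `O=C(O)CC/C=C\CC1COC(c2cccs2)OC1c1cccnc1`, and its difference from compound 2 is thiophen-2-yl in place of thiophen-3-yl on a saturated ring carbon. Thiophen-2-yl takes the place of thiophen-3-yl on a saturated ring carbon, between two ring oxygen atoms, and the two compounds have the same atoms, joined differently.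

Among the measured compounds shown here, one measured step bears on this carbon. Exchanging 4-(trifluoromethyl)phenyl for thiophen-3-yl there gave a 1.1-fold lower number from compound 1 to compound 2 (0.05 log units; within the scatter). For the measured compounds named here, no measurement yet covers a swap between the two thiophene attachments, so this single step is the only guide. It gives no direction, and no change beyond the scatter is expected. The estimate means a 1.0-fold higher number from compound 2 to compound 3 (0.01 log units; within the scatter), an expected step within the scatter. Compound 3 is expected at 1600 nM, with an estimated range of 800 nM to 3200 nM.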

Compound 3, dissociation constant: 1000 nM
Compound 3: the middle estimate sits 1.6-fold (0.20 log units) above what was measured; the range from low to high includes it.
By their numbers in this assay, from the lowest: compounds 3, 2 and 1 (each within the scatter of the next).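

Moving the attachment point of the thiophene ring on this saturated ring carbon, between two ring oxygen atoms, is the first change here that keeps the same atoms and joins them differently, and in this assay it gives a 1.6-fold lower number from compound 2 to compound 3 (0.20 log units; within the scatter). The comparison of the thiophen-2-yl group with the 4-(trifluoromethyl)phenyl group gives a 1.8-fold lower number from compound 1 to compound 3 (0.25 log units; within the scatter), so every step among the three compounds now lies within the scatter, and the earlier finding for thiophen-3-yl extends to a second thiophene attachment and does not depend on how that ring is joined. No evidence is available that would explain this tolerance at the position.

The compounds shown leave open whether a group of another kind on this carbon, such as an amine, a carboxylic acid or a longer alkyl chain, would give a step beyond the scatter. They also leave open how the number responds to changes elsewhere, since the pyridin-3-yl and 5-carboxypent-2-en-1-yl groups stay the same throughout.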